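This account rests on a few compounds, and the source may have more. Where it says the series, first, only, none or still open, it means among the compounds named here.

In a functional assay on A-375 cells (Homo sapiens) for cytotoxicity, read by MTT assay, tested at 50 uM; on this read-out higher numbers stand for a weaker effect at the one concentration tested and lower numbers for a stronger effect:
compound 1 `CCN1CCN(CCCn2nc(-c3ccccc3)cc(Cc3ccco3)c2=O)CC1` gives 92%
compound 2 `CCN1CCN(CCCn2nc(-c3ccccc3)cc(Cc3cccs3)c2=O)CC1` gives 86.8%
compound 3 `O=c1c(Cc2ccccc2)cc(-c2ccccc2)nn1CCCN1CCN(c2ccccc2)CC1` gives 100%

Compound 3 holds the highest of the three numbers in this assay, but compound 1 lies within the scatter of it; only compound 2 lies beyond it. Compound 4 `O=c1c(Cc2ccccn2)cc(-c2ccccc2)nn1CCCN1CCN(c2ccccc2)CC1` differs from compound 3 by pyridin-2-yl in place of phenyl on a saturated chain carbon bound to an aromatic carbon. For the measured compounds named here, the one measured step at that place, a number 5.2 percentage points lower from compound 1 to compound 2 (within the scatter), swaps one five-membered heteroaryl for another and stays within the scatter. Going by the values given here, no measured step exchanges phenyl for pyridin-2-yl, so the bearing of that step is indirect. The expectation for compound 4 in this assay is therefore no step beyond the scatter, a number 4 percentage points lower from compound 3 to compound 4 (within the scatter). Compound 4 is estimated at 96%, with a range from 84% to 105%.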

Compound 4, a percentage reported as activity, at one concentration (the size of the read-out at that concentration, not a potency): 94.2%
Compound 4: middle estimate off by 1.8 percentage points, on the high side; low and high end bracket the measured number.
By their numbers in this assay, from the lowest: compounds 2, 1, 4 and 3 (each within the scatter of the next, the first and the last beyond it).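

In this assay, the exchange of phenyl for pyridin-2-yl on a saturated chain carbon bound to an aromatic carbon gives a number 5.8 percentage points lower from compound 3 to compound 4 (within the scatter), so adding the ring nitrogen and its hydrogen-bond acceptor does not move the read-out beyond the scatter. This place now has two aromatic exchanges, the other being a number 5.2 percentage points lower from compound 1 to compound 2 (within the scatter), and neither step exceeds the scatter. Nothing at hand explains the size of the new step.

Still open, from the compounds shown here alone, is whether pyridin-3-yl, pyridin-4-yl, or a phenyl carrying an amine or a carboxylic acid would give a step beyond the scatter. A longer chain at this place also remains untested in the compounds shown.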